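The compounds below may be only part of what the source reports. "The series", "measured", "known", "first", "only" and "open" are said of these compounds alone.

Measured compounds:
compound 1, `COc1ccccc1C(=O)Nc1cccc(NC(=O)c2cccc(F)c2)c1`, with 6480 nM in an in vitro functional assay on HEK293-A cells for antagonist activity at metabotropic glutamate receptor 5 (Rattus norvegicus), read by calcium flux; on this read-out higher numbers stand for weaker inhibition and lower numbers for stronger inhibition
compound 2, `COc1ccccc1C(=O)Nc1cccc(NC(=O)C2CCC2)c1`, for which this assay reports only a limit, > 30000 nM
compound 3, `COc1ccccc1C(=O)Nc1cccc(NC(=O)C2CC2)c1`, for which this assay again reports only a limit, > 30000 nM

Compound 1 is the only one of the three with a measured number in this assay. Compound 2 stands at the limit, and so does compound 3; the limit of > 30000 nM in this assay, at which 2 of the 3 values shown sit, is where both of them sit. From compound 1 the step is an at least 4.6-fold higher number from compound 1 to compound 2 (0.66 log units; beyond the scatter), and the parallel step is an at least 4.6-fold higher number from compound 1 to compound 3 (0.66 log units; beyond the scatter). The step that the two limits leave unreadable from compound 2 to compound 3 cannot be read, since both ends are limits.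

Compound 4, `O=C(Nc1cccc(NC(=O)C2CCC2)c1)c1cccc(Cl)c1`, is not yet measured. It differs from compound 2 by 3-chlorophenyl in place of 2-methoxyphenyl on a carbonyl carbon. Among the measured compounds shown here, none of the measured steps touches this side of the core: all three concern the group on the other carbonyl, and compound 4 keeps the cyclobutyl of compound 2 there. The measured steps therefore bear on compound 4 only in that its cyclobutyl partner has so far only given limits. Compound 4 is thus expected to stay near the limit, the expected step being a number no higher from compound 2 to compound 4 (the limit leaves the size open). The estimate for compound 4 is 30000 nM, in a range from 8000 nM to 100000 nM.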

Compound 4, half-maximal inhibitory concentration: 5270 nM
Beside the measured number, compound 4's estimate is 5.7-fold (0.76 log units) above it; the whole stated range lies above it.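

In this assay, the carbonyl that carries 2-methoxyphenyl in compound 2 proves to be a second place where the read-out responds: with cyclobutyl kept on the other carbonyl, 3-chlorophenyl in its place brings an at least 5.6-fold lower number from compound 2 to compound 4 (0.75 log units; beyond the scatter). The earlier compounds shown here varied only the other carbonyl, and cyclobutyl had appeared there only with a limit, so compound 4 shows that a cyclobutyl compound can return a measured number once this aryl group changes. Only one end of this step is a number, and its full size stays open, since compound 2 stands at a limit: the limit of > 30000 nM in this assay, at which 2 of the 4 values shown sit.

The compounds shown leave open whether the change owes more to the arrival of 3-chlorophenyl or to the departure of 2-methoxyphenyl, a question that an unsubstituted phenyl or a 3-methoxyphenyl on this carbonyl would help to separate. They also leave open whether 3-chlorophenyl has the same effect when cyclopropyl or 3-fluorophenyl stands on the other carbonyl.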